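Methylsulfanyl for Fluoro: Expecting Little Change in Compound 4

The source may report more compounds than this note shows. Statements on the series, on what has been measured and on what is new or still open speak of the compounds shown alone.

Compound 3 `NC(=O)c1c(NC(=O)c2ccccc2F)sc2c1CCN(C(=S)Nc1ccccc1Cl)C2` gives 12500 nM in a functional assay on HL-60 cells (Homo sapiens) for antiproliferative activity, with a stated time of 24 h; on this read-out lower numbers stand for stronger inhibition and higher numbers for weaker inhibition. Among the three measured compounds it holds the second highest number: compound 2 `NC(=O)c1c(NC(=O)c2ccccc2F)sc2c1CCN(Cc1c(Cl)cccc1Cl)C2` gives 10300 nM, and compound 1 `NC(=O)c1c(NC(=O)c2ccccc2F)sc2c1CCN(Cc1cccc(Cl)c1)C2` gives 19800 nM. The steps of a 1.2-fold higher number from compound 2 to compound 3 (0.08 log units; within the scatter) and a 1.6-fold lower number from compound 1 to compound 3 (0.20 log units; within the scatter) lie within the scatter, as does a 1.9-fold lower number from compound 1 to compound 2 (0.28 log units; within the scatter). Compound 4 `CSc1ccccc1C(=O)Nc1sc2c(c1C(N)=O)CCN(C(=S)Nc1ccccc1Cl)C2` differs from compound 3 by methylsulfanyl in place of fluoro on an aromatic carbon. For the measured compounds named here, none of the measured steps touches this part of the molecule; all three exchange the group on the amine nitrogen in the ring, and all three stay within the scatter. Going by the values given here, no measured step bears on this change, so the step expected for compound 4 is no change at the digits printed from compound 3 to compound 4 (within the scatter), essentially none beyond the scatter. The estimate for compound 4 in this assay is 12500 nM, with a range from 4000 nM to 40000 nM.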

Compound 4, half-maximal inhibitory concentration: 30500 nM
Compound 4: middle estimate off by 2.4-fold (0.39 log units), on the low side; low and high end bracket the measured number.
By their numbers in this assay, from the lowest: compounds 2, 3, 1 and 4 (each within the scatter of the next, the first and the last beyond it).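

Unlike the three earlier steps, all on the amine nitrogen in the ring and all within the scatter, this change on the aromatic ring gives a step beyond the scatter. In this assay, methylsulfanyl in place of fluoro brings a 2.4-fold higher number from compound 3 to compound 4 (0.39 log units; beyond the scatter), so this position is not indifferent to the group it carries, although the step is modest. No measurement here accounts for the step. Still open, as far as these compounds go, is how other groups here would read, such as chloro, methoxy or an amine. Also open, from the compounds shown here alone, is whether the same exchange gives a similar step with the group of compound 2 on the amine nitrogen.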